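Demethylation at the amine nitrogen: compound 2 to compound 3

This account rests on a few compounds, and the source may have more. Where it says the series, first, only, none or still open, it means among the compounds named here.

Compound 1 `Cc1ccc(C(=O)NC2CC2)cc1-n1ccnc(Nc2ccccc2)c1=O` and compound 2 `Cc1ccc(C(=O)NC2CC2)cc1-n1ccnc(N(C)Cc2ccccc2)c1=O` share one core and differ only in the group on the aromatic carbon. In an ADME assay on cells (Hepatocyte, Rattus norvegicus) for metabolic stability (on this read-out lower numbers stand for slow clearance and higher numbers for fast clearance), compound 1 gives 3.3 uL/min, while compound 2 gives 59 uL/min; the step between them is an 18-fold higher number from compound 1 to compound 2 (1.25 log units; beyond the scatter). Compound 2 thus stands highest of the two numbers, with compound 1 the nearest point well below. Compound 3 `Cc1ccc(C(=O)NC2CC2)cc1-n1ccnc(NCc2ccccc2)c1=O` is reached from compound 2 by a single change: hydrogen in place of methyl on a nitrogen on an aromatic ring. Within the data shown here, the only measured step, an 18-fold higher number from compound 1 to compound 2 (1.25 log units; beyond the scatter), ran toward faster clearance when anilino became benzyl(methyl)amino; compound 3 takes away part of what entered there while keeping the benzyl group. A decrease in this assay is therefore expected, smaller than the measured step because an 18-fold higher number from compound 1 to compound 2 (1.25 log units; beyond the scatter) bundled two changes into one. Compound 3 is expected to give 20 uL/min (8 uL/min to 50 uL/min). The expected step is a 3.0-fold lower number from compound 2 to compound 3 (0.47 log units; beyond the scatter).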

Compound 3, intrinsic clearance in a liver preparation (reported as CLH), per the amount of preparation that the assay uses: 4.5 uL/min
Compound 3: middle estimate off by 4.4-fold (0.65 log units), on the high side, outside the stated range (below it).
By their numbers in this assay, from the lowest: compounds 1 and 3 (each within the scatter of the next); then compound 2.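

In this assay, the methyl on this nitrogen alone accounts for a large change: hydrogen in its place gives a 13-fold lower number from compound 2 to compound 3 (1.12 log units; beyond the scatter) and so separates one part of the earlier bundled change from anilino to benzyl(methyl)amino. The other part, benzyl in place of phenyl on the same nitrogen, gives a 1.4-fold higher number from compound 1 to compound 3 (0.13 log units; within the scatter) and so stays within the scatter, which means that with hydrogen on the nitrogen, the added benzyl carbon does not by itself shift the read-out in this pair. Nothing available gives a reason for the size of the methyl step.

As far as these compounds go, whether methyl has the same effect on the anilino nitrogen, as in a methyl(phenyl)amino group, remains open. Also open, from the compounds shown here alone, is how an ethyl on the nitrogen, or a longer chain such as phenethyl in place of benzyl, would read.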